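Ethyl-amide series: piperidinyl for methylpiperazinyl on the aryl ring

The source may report more compounds than this note shows. Statements on the series, on what has been measured and on what is new or still open speak of the compounds shown alone.

Compound 3 `CCN1C(=O)CN(C2CCCC2)c2nc(Nc3ccc(N4CCN(C)CC4)cc3)ncc21`, in an ADME assay on HEK293 cells (Homo sapiens) for inhibition, read by MTT assay, with a stated time of 48 h (on this read-out higher numbers stand for weaker inhibition and lower numbers for stronger inhibition), gives only a limit: > 30000 nM; it is one of the values at the limit of > 30000 nM in this assay, at which 1 of the 3 values shown sits. Compound 1 `O=C1CN(C2CCCC2)c2nc(Nc3ccc(N4CCCCC4)cc3)ncc2N1`, which carries the piperidin-1-yl group and the amide hydrogen, gives 25100 nM in this assay. The methyl analogue is compound 2 `CN1C(=O)CN(C2CCCC2)c2nc(Nc3ccc(N4CCCCC4)cc3)ncc21`, and in this assay compound 2 gives 25300 nM; the step of a 1.0-fold higher number from compound 1 to compound 2 (0.00 log units; within the scatter) shows that this change leaves the read-out where it was. Compound 4 `CCN1C(=O)CN(C2CCCC2)c2nc(Nc3ccc(N4CCCCC4)cc3)ncc21` is not yet measured; it differs from compound 3 by piperidin-1-yl in place of 4-methylpiperazin-1-yl on an aromatic carbon. Among the measured compounds shown here, no measured step covers this exchange directly; what bears on it is only that compound 1 and compound 2, both with the piperidin-1-yl group, sit near the limit, and that compound 3 sits at it. The expected step of an at least 1.0-fold lower number from compound 3 to compound 4 (0.02 log units; that floor lies within the scatter) is therefore none beyond the scatter. Compound 4 is estimated at 28000 nM in this assay, with a range from 15000 nM to 60000 nM, and a reported limit rather than a number is plausible.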

Compound 4, half-maximal inhibitory concentration: > 30000 nM
Compound 4 gave a limit, no number; the forecaster's own chance of this, stated with the estimate: 45%; at least 1.0-fold (0.02 log units) between middle value and limit.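

Compound 4, like compound 3, is reported only as a limit in this assay, so the exchange of 4-methylpiperazin-1-yl for piperidin-1-yl on this aromatic carbon gives a step that cannot be read: the limit of > 30000 nM in this assay, at which 2 of the 4 values shown sit.

With piperidin-1-yl held constant, ethyl in place of the amide hydrogen gives an at least 1.1-fold higher number from compound 1 to compound 4 (0.07 log units; that floor lies within the scatter), and ethyl in place of methyl gives an at least 1.1-fold higher number from compound 2 to compound 4 (0.07 log units; that floor lies within the scatter). Both floors lie within the scatter, so hydrogen, methyl and ethyl on this amide-type nitrogen show no change beyond it, though the limit leaves the true size of both steps unknown.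

Still open, going by these compounds, is how far compound 3 and compound 4 each lie past the limit. Also open, on these data alone, is whether a primary amine or a carboxylic acid in place of piperidin-1-yl, or a propyl chain on the amide-type nitrogen, would give a number inside the range of the assay.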